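A few compounds are considered here, and "the series" means these few. Any claim that something is new, unique, unknown or untested is made for them only; others in the source may bear on it.

Three compounds share one core and differ only in the aryl group carried on the saturated chain carbon of the benzyl ether. In a functional assay on HT-29 cells (Homo sapiens) for inhibition, read by MTT assay, with a stated time of 48 h (a higher number here means a weaker inhibitor, a lower number a stronger inhibitor), compound 1 `Cc1ccc(NC(=S)NC(=O)c2ccc(OCc3ccccc3F)cc2)cc1-c1nc2ccccc2[nH]1` gives 1870 nM. Compound 2 `Cc1ccc(NC(=S)NC(=O)c2ccc(OCc3cccc(F)c3)cc2)cc1-c1nc2ccccc2[nH]1` gives 55300 nM. Compound 3 `Cc1ccc(NC(=S)NC(=O)c2ccc(OCc3ccc(Cl)c(Cl)c3)cc2)cc1-c1nc2ccccc2[nH]1` gives 6270 nM. Among these three numbers compound 3 stands second highest, since there is a 3.4-fold higher number from compound 1 to compound 3 (0.53 log units; beyond the scatter) and an 8.8-fold lower number from compound 2 to compound 3 (0.95 log units; beyond the scatter). Compound 4 `O=C(NC(=S)Nc1ccc(Cl)c(-c2nc3ccccc3[nH]2)c1)c1ccc(OCc2ccc(Cl)c(Cl)c2)cc1` keeps the 3,4-dichlorophenyl of compound 3 and alters another place: chloro in place of methyl on an aromatic carbon. Among the measured compounds shown here, no measured step touches this position; all of them vary the aryl group on the benzyl ether, among them a 30-fold higher number from compound 1 to compound 2 (1.47 log units; beyond the scatter). The data give no guidance here, so in this assay no step beyond the scatter is expected. Compound 4 is estimated at 6000 nM, between 2000 nM and 20000 nM, which is expected to mean a 1.0-fold lower number from compound 3 to compound 4 (0.02 log units; within the scatter).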

Compound 4, half-maximal inhibitory concentration: 4930 nM
For compound 4 the middle estimate is 1.2-fold (0.09 log units) above the measured one, within the range that was stated.
By their numbers in this assay, from the lowest: compound 1; then compounds 4 and 3 (each within the scatter of the next); then compound 2.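

The earlier steps shown here all varied the aryl group on the benzyl ether, whereas this one changes the aromatic carbon ortho to the 1H-benzimidazol-2-yl group. In this assay, chloro in place of methyl gives a 1.3-fold lower number from compound 3 to compound 4 (0.10 log units; within the scatter) and so makes no difference beyond the scatter when the 3,4-dichlorophenyl is present. No measurement here bears on this result.

From the compounds shown here alone, whether an amine or a carboxylic acid at this position would shift the number remains open. So does whether the same change would behave alike with the 2-fluorophenyl of compound 1 or the 3-fluorophenyl of compound 2.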